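Lengthening the ester chain on the aniline nitrogen

The compounds below may be only part of what the source reports. "The series", "measured", "known", "first", "only" and "open" are said of these compounds alone.

Measured in a functional assay on DU-145 cells (Homo sapiens) for cytotoxicity, read by trypan blue exclusion, with a stated time of 96 h; a higher number here means a weaker inhibitor, a lower number a stronger inhibitor:
- compound 1 `COc1cc(OC)c(/C=C/S(=O)(=O)Cc2ccc(OC)c([N+](=O)[O-])c2)c(OC)c1`: 2500 nM
- compound 2 `COc1cc(OC)c(/C=C/S(=O)(=O)Cc2ccc(OC)c(N)c2)c(OC)c1`: 4 nM
- compound 3 `COC(=O)CNc1cc(CS(=O)(=O)/C=C/c2c(OC)cc(OC)cc2OC)ccc1OC`: 100 nM

Compound 3 stands in the middle of the three, with a 25-fold lower number from compound 1 to compound 3 (1.40 log units; beyond the scatter) on one side and a 25-fold higher number from compound 2 to compound 3 (1.40 log units; beyond the scatter) on the other. All measured steps are large, including a 630-fold lower number from compound 1 to compound 2 (2.80 log units; beyond the scatter), but that one replaces the nitro group and offers little guidance on chain length.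

The next compound is compound 4 `COC(=O)CCNc1cc(CS(=O)(=O)/C=C/c2c(OC)cc(OC)cc2OC)ccc1OC`. It differs from compound 3 as follows: (methoxycarbonyl)methyl in place of methoxycarbonyl on a saturated chain carbon bound to a nitrogen on an aromatic ring. In words, this is (methoxycarbonyl)methyl in place of methoxycarbonyl on a saturated chain carbon bound to a nitrogen on an aromatic ring, so (methoxycarbonyl)methyl becomes 2-(methoxycarbonyl)ethyl.

Among the measured compounds shown here, no measured step makes this change. The closest evidence is a 25-fold higher number from compound 2 to compound 3 (1.40 log units; beyond the scatter), which shows that substitution on this nitrogen can shift the number strongly. That step adds the whole ester chain to a free amino group, whereas compound 4 keeps the chain and extends it, so a much smaller shift is expected here, with a slight lean towards a higher number. The expected step is a 1.5-fold higher number from compound 3 to compound 4 (0.18 log units; within the scatter).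

For compound 4 the estimate is 150 nM, with an expected range of 40 nM to 600 nM.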

Compound 4, half-maximal inhibitory concentration: 1500 nM
For compound 4 the middle estimate is 10-fold (1.00 log units) below the measured one, and the stated range ends below it.
By their numbers in this assay, from the lowest: compound 2; then compound 3; then compounds 4 and 1 (each within the scatter of the next).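

In this assay, the length of the chain on this nitrogen matters in its own right: going from (methoxycarbonyl)methyl to 2-(methoxycarbonyl)ethyl gives a 15-fold higher number from compound 3 to compound 4 (1.18 log units; beyond the scatter), so a change within the substituent can shift the number strongly, not only adding the substituent to the free amino group. Measured against that free amino group, the longer chain gives a 380-fold higher number from compound 2 to compound 4 (2.57 log units; beyond the scatter), while replacing nitro with (2-(methoxycarbonyl)ethyl)amino gives a 1.7-fold lower number from compound 1 to compound 4 (0.22 log units; within the scatter), so this chain leaves no measurable advantage over the nitro compound. Nothing available explains why this change has such a large effect.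

Among compounds 2, 3 and 4, the number rises from the free amino group through the shorter ester chain to the longer one, with no compound against that order, but three compounds cannot show whether the rise continues with a longer chain such as 3-(methoxycarbonyl)propyl. Also open, on these data alone, is whether the ester itself contributes to these steps, a question that a carboxylic acid or an amide at the end of the same chain, or a plain methyl group on the nitrogen, would address.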